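Bis-enone series: aryl swap on the exocyclic chain carbon

A few compounds are considered here, and "the series" means these few. Any claim that something is new, unique, unknown or untested is made for them only; others in the source may bear on it.

Measured compounds:
- compound 1, `COc1cccc(/C=C/C(=O)C(=Cc2ccc(O)c(F)c2)C(=O)/C=C/c2cccc(OC)c2OC)c1OC`: 200 nM
- compound 2, `COc1cc(C=C(C(=O)/C=C/c2cccc(OC)c2OC)C(=O)/C=C/c2cccc(OC)c2OC)cc(Br)c1O`: 200 nM
- compound 3, `COc1ccc(/C=C/C(=O)C(=Cc2ccc(O)c(F)c2)C(=O)/C=C/c2ccc(OC)cc2OC)c(OC)c1`: 2070 nM

In a functional assay on A549 cells (Homo sapiens) for antiproliferative activity, read by sulforhodamine B assay, with a stated time of 48 h (on this read-out higher numbers stand for weaker inhibition and lower numbers for stronger inhibition), compound 1 gives 200 nM and compound 2 gives 200 nM. These two share one core and differ in one place only, by 3-bromo-4-hydroxy-5-methoxyphenyl in place of 3-fluoro-4-hydroxyphenyl on a double-bonded chain carbon bound to a double-bonded chain carbon. The step this makes is no change at the digits printed from compound 1 to compound 2 (within the scatter), so the two values sit within the scatter of each other and no order between them is claimed.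

Compound 3 has the same atoms as compound 1 joined differently; the difference between the two cores is not broken down here. In this assay compound 3 gives 2070 nM, the highest number of the three, and its gap to each of compound 1 and compound 2 lies beyond the scatter.

Compound 4, `COc1ccc(/C=C/C(=O)C(=Cc2cc(Br)c(O)c(OC)c2)C(=O)/C=C/c2ccc(OC)cc2OC)c(OC)c1`, is not yet measured. It stands to compound 3 as compound 2 stands to compound 1: the change is 3-bromo-4-hydroxy-5-methoxyphenyl in place of 3-fluoro-4-hydroxyphenyl on a double-bonded chain carbon bound to a double-bonded chain carbon, the same kind of change, with the place described in the same words for both pairs. On the core of compound 1 this change left the read-out where it was, as no change at the digits printed from compound 1 to compound 2 (within the scatter) shows. Within the data shown here, on the core of compound 3 the step from compound 3 to compound 4 is therefore expected to be of about the same size, that is a 1.0-fold lower number from compound 3 to compound 4 (0.01 log units; within the scatter), resting on the one earlier pair only; a second core could behave differently, and nothing here tests that. For compound 4 in this assay the estimated value is 2000 nM, expected to fall between 600 nM and 7000 nM.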

Compound 4, half-maximal inhibitory concentration: 1090 nM
Compound 4: the middle estimate sits 1.8-fold (0.26 log units) above what was measured; low and high end bracket the measured number.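

In this assay, moving the core of compound 3 from 3-fluoro-4-hydroxyphenyl to 3-bromo-4-hydroxy-5-methoxyphenyl on a double-bonded chain carbon bound to a double-bonded chain carbon gives a 1.9-fold lower number from compound 3 to compound 4 (0.28 log units; within the scatter), so on this second core too the two values cannot be ordered. Set beside the earlier pair, the change reads alike on both cores, with no gap that can be told from scatter: the same change on two cores in this assay, no change at the digits printed (within the scatter) from compound 1 to compound 2 and a 1.9-fold lower number (0.28 log units; within the scatter) from compound 3 to compound 4, 1.9-fold (0.28 log units) apart, within the scatter of two such steps. This supports carrying the change between these two cores with little expected shift in the read-out, but it rests on one pair per core, does not show that a further core would behave the same way, and, with both steps inside the scatter, gives no sign that the entering group is better or worse than the leaving one.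

The compounds shown leave open how the read-out responds when the aryl group at this place carries an amine, a carboxylic acid or a longer alkoxy chain instead of the halogen and methoxy groups seen here. They also leave open whether the same change would still read alike with an unsubstituted phenyl on the two enone arms.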